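The source may hold more compounds than are shown below. What is called first, only, known or untested is meant among the compounds shown, and "the series" means these compounds.

Measured compounds:
compound 1 `CCN(CC)C(=O)CN(c1ccc(C)cc1)S(=O)(=O)c1ccc(OC(F)(F)F)cc1` — > 10000 nM
compound 2 `CCN(C(=O)CN(c1cc(N(C)C)ccc1Cl)S(=O)(=O)c1ccc(OC)c(OC)c1)c1cccc(C)n1` — 17 nM

Two compounds have been run in a functional assay on CHO cells for inhibition of Orexin/Hypocretin receptor type 1 (Homo sapiens), read by FLIPR and calcium flux; on this read-out lower numbers stand for stronger inhibition and higher numbers for weaker inhibition. Compound 1 `CCN(CC)C(=O)CN(c1ccc(C)cc1)S(=O)(=O)c1ccc(OC(F)(F)F)cc1` returns > 10000 nM, which is a limit of the assay rather than a number. Of the two values shown, one sits at the limit of > 10000 nM in this assay, at which 1 of the 2 values shown sits. Among the measured compounds shown here, compound 2 `CCN(C(=O)CN(c1cc(N(C)C)ccc1Cl)S(=O)(=O)c1ccc(OC)c(OC)c1)c1cccc(C)n1` gives 17 nM, the only actual number in the set, so it stands as the sole measured point of reference. For the measured compounds named here, no pair of measured compounds differs in a single place, so no step size has been established.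

Compound 3 `CCN(C(=O)CN(c1cc(N(C)C)ccc1Cl)S(=O)(=O)c1ccc(OC)c(OC)c1)c1ccn(C)n1` has not yet been measured. It differs from compound 2 by 1-methyl-1H-pyrazol-3-yl in place of 6-methylpyridin-2-yl on an amide-type nitrogen. Going by the values given here, with no measured step to draw on, the expectation rests on compound 2 alone. The change from compound 2 to compound 3 is expected to be a 2.4-fold higher number from compound 2 to compound 3 (0.37 log units; beyond the scatter) in this assay, a modest loss that may still fall within scatter. Compound 3 is therefore estimated at 40 nM, with a range from 10 nM to 200 nM.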

Compound 3, half-maximal inhibitory concentration: 12 nM
Compound 3: the middle estimate sits 3.3-fold (0.52 log units) above what was measured, within the range that was stated.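

Among the compounds shown here, at the amide-type nitrogen, whose other neighbours are a carbonyl carbon and a saturated chain carbon, the first exchange of one ring for another can now be read in this assay: with 1-methyl-1H-pyrazol-3-yl in place of 6-methylpyridin-2-yl, the result is a 1.4-fold lower number from compound 2 to compound 3 (0.15 log units; within the scatter), so the two compounds cannot be told apart. A five-membered aromatic ring with 2 hetero atoms thus serves here as well as a six-membered aromatic ring with 1 hetero atom, which shows that, in this read-out, this place is not tied to the one ring seen earlier. Nothing in the information at hand bears on why the two rings give matching results.

Going by these compounds, two rings do not show how wide this freedom is, so it remains open whether a plain phenyl, a pyrimidine, a saturated piperidine or either ring without its methyl group would hold the value at this nitrogen. On these data alone, it also remains open whether the ethyl on the same nitrogen could give way to a hydrogen or a longer chain such as propyl.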